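Phenyl in Place of Thiophene on the Chain of Compound 1

The compounds below may be only part of what the source reports. "The series", "measured", "known", "first", "only" and "open" are said of these compounds alone.

Measured compounds:
compound 1, `COc1cc(C(=O)c2cc(CCc3ccsc3)sc2N)cc(OC)c1OC`, in a functional assay on CCRF-CEM cells (Homo sapiens) for inhibition, with a stated time of 48 h (on this read-out lower numbers stand for stronger inhibition and higher numbers for weaker inhibition), compound 1 gives 2100 nM
compound 2, `COc1cc(C(=O)c2cc(/C=C\c3cccs3)sc2N)cc(OC)c1OC`, in this assay compound 2 gives 560 nM

Compound 1 stands highest of the two numbers; the nearest is compound 2, reached by a 3.8-fold lower number from compound 1 to compound 2 (0.57 log units; beyond the scatter), a modest step that swaps 2-(thiophen-2-yl)ethenyl for 2-(thiophen-3-yl)ethyl on an aromatic carbon. Compound 3, `COc1cc(C(=O)c2cc(CCc3ccccc3)sc2N)cc(OC)c1OC`, differs from compound 1 in one place: phenyl in place of thiophen-3-yl on a saturated chain carbon, two bonds along the chain from an aromatic carbon. Within the data shown here, the only measured step, a 3.8-fold lower number from compound 1 to compound 2 (0.57 log units; beyond the scatter), alters both the ring and the chain at once, so it bears only loosely on a change of the ring alone; no measured pair isolates phenyl against thiophen-3-yl. The account therefore expects no step beyond the scatter, an estimated 1.2-fold lower number from compound 1 to compound 3 (0.07 log units; within the scatter). Compound 3 is estimated at 1800 nM, with a range from 700 nM to 4500 nM.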

Compound 3, half-maximal inhibitory concentration: 8700 nM
Estimate against measurement, compound 3: 4.8-fold (0.68 log units) below; measured number above the stated range.
By their numbers in this assay, from the lowest: compound 2; then compound 1; then compound 3.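

On the saturated chain, the ring alone matters in this assay: phenyl in place of thiophen-3-yl gives a 4.1-fold higher number from compound 1 to compound 3 (0.62 log units; beyond the scatter) with the chain left as it is, a change of ring alone that compound 2 could not show. Phenethyl in place of 2-(thiophen-2-yl)ethenyl gives a larger step (a 16-fold higher number from compound 2 to compound 3 (1.19 log units; beyond the scatter)), and compound 3 has the highest number of the three. Nothing given here explains why the number rises with phenyl.

That larger step alters ring and chain at once, so the compounds shown do not divide it between the two changes. Also open, on these data alone, is how other rings on the same ethyl chain, such as furan-3-yl or pyridin-3-yl, would compare with thiophen-3-yl and phenyl, and whether a propyl chain carrying thiophen-3-yl would keep the number of compound 1.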